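From bromo to methyl in a growth-inhibition series

The source may hold more compounds than are shown below. What is called first, only, known or untested is meant among the compounds shown, and "the series" means these compounds.

Compound 1 `CCOC(=O)c1nn(-c2ccc(Cl)cc2)c(-c2ccc(C)cc2)c1CNC(C)(C)C`: 151000 nM; > 542000 nM (2 entries) (several entries)
Compound 2 `Cc1ccc(-c2c(CNC(C)(C)C)c(C(=O)O)nn2-c2ccccc2)cc1`: > 688000 nM (a limit)
Compound 3 `CC(C)(C)NCc1c(C(=O)O)nn(-c2ccc(Cl)cc2)c1-c1ccc(Br)cc1`: > 542000 nM (a limit)

All three were tested in a functional assay on U-251 cells (Homo sapiens) for inhibition, read by sulforhodamine B assay, with a stated time of 48 h; a lower number here means a stronger inhibitor of growth, a higher number a weaker inhibitor of growth. Compound 3 has only a limit, > 542000 nM, and no exact number. Compound 4 `Cc1ccc(-c2c(CNC(C)(C)C)c(C(=O)O)nn2-c2ccc(Cl)cc2)cc1` has methyl in place of bromo on an aromatic carbon, para to a large group: methyl in place of bromo on an aromatic carbon. Going by the values given here, no measured pair shows this change. Compound 2 also carries the 4-methylphenyl group and has only a limit, > 688000 nM. A step beyond the usual scatter is therefore not expected in either direction in this assay. The expected change is small: a step that the limit leaves unreadable from compound 3 to compound 4. For compound 4 the estimated value is 620000 nM, with an expected range of 250000 nM to 900000 nM.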

Compound 4, concentration for 50% growth inhibition: > 629000 nM
Compound 4 was reported as a limit; the forecaster's own chance of this, stated with the estimate: 80%; middle value at least 1.0-fold (0.00 log units) away from the limit.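

Going by these compounds alone, compound 4 gives only a limit, > 629000 nM; compound 2 and compound 3 also give only limits, so no step to compound 4 can be read. Going by these compounds, whether methyl in place of bromo changes growth inhibition stays open.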